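The source may report more compounds than this note shows. Statements on the series, on what has been measured and on what is new or still open speak of the compounds shown alone.

Measured so far in a functional assay on NCI-H460 cells (Homo sapiens) for inhibition, read by sulforhodamine B assay, with a stated time of 48 h; on this read-out lower numbers stand for stronger inhibition of growth and higher numbers for weaker inhibition of growth:
compound 1, `COC(=O)c1sc2cc(C#Cc3ccc(OC)cc3)cnc2c1N`, gives 320 nM;
compound 2, `COC(=O)c1sc2cc(C#Cc3ccc(N)cc3)cnc2c1N`, gives 8900 nM;
compound 3, `COC(=O)c1sc2cc(C#Cc3ccccc3OC)cnc2c1N`, gives only a limit of this assay, > 47300 nM.

Compound 3 thus stands weakest of the three: its value is the limit of > 47300 nM in this assay, at which 1 of the 3 values shown sits, a limit and not a number. Its steps from the two measured compounds are both large, an at least 140-fold higher number from compound 1 to compound 3 (2.16 log units; beyond the scatter) and an at least 5.3-fold higher number from compound 2 to compound 3 (0.72 log units; beyond the scatter), and in each of them the 2-methoxyphenyl entered on the triple-bonded carbon. The move to compound 4, `COC(=O)c1sc2cc(C#Cc3ccsc3)cnc2c1N`, is thiophen-3-yl in place of 2-methoxyphenyl on a triple-bonded carbon. It takes away the very group that went with both large losses, and the thiophen-3-yl that enters carries no methoxy at all. For the measured compounds named here, no measured compound holds a thiophene, so the size of the step can only be judged loosely: the two steps into compound 3 suggest that leaving the 2-methoxyphenyl should move the number down, toward the region of compound 1 and compound 2, but the starting point is a limit, so the true distance is unknown. Compound 4 is therefore expected to show a downward step, an at least 9.4-fold lower number from compound 3 to compound 4 (0.97 log units; beyond the scatter), beyond the scatter. The estimated value of compound 4 is 5000 nM, with a range from 700 nM to 40000 nM.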

Compound 4, concentration for 50% growth inhibition: 24800 nM
Beside the measured number, compound 4's estimate is 5.0-fold (0.70 log units) below it; the range from low to high includes it.
By their numbers in this assay, from the lowest: compound 1; then compound 2; then compound 4. At a limit, above all of these: compound 3.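

In this assay, thiophen-3-yl on the triple-bonded carbon gives a real number, but it falls well short of the 4-methoxyphenyl, with a 78-fold higher number from compound 1 to compound 4 (1.89 log units; beyond the scatter), and short of the 4-aminophenyl by a smaller margin, with a 2.8-fold higher number from compound 2 to compound 4 (0.45 log units; beyond the scatter), so compound 1 stays the strongest of the four, all its steps being beyond the scatter. Whether leaving the 2-methoxyphenyl helps at all cannot be settled, since the comparison gives only a floor, an at least 1.9-fold lower number from compound 3 to compound 4 (0.28 log units; that floor lies within the scatter), and that floor does not clear the usual spread of repeated measurements. Compound 3 remains a limit and not a number: the limit of > 47300 nM in this assay, at which 1 of the 4 values shown sits.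

This change swaps the ring and removes the methoxy group together, so the compounds shown cannot separate what each of the two contributes. Open too, from the compounds shown here alone, is how a plain phenyl, a 3-methoxyphenyl, a thiophen-2-yl or a pyridine ring would stand on the triple-bonded carbon, and whether a methoxy group on the thiophene ring would bring the number closer to that of compound 1.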